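Chalcones with Varied Alkoxy Groups: Cytotoxicity Estimate

A few compounds are considered here, and "the series" means these few. Any claim that something is new, unique, unknown or untested is made for them only; others in the source may bear on it.

The measured compounds:
Compound 1, `COc1ccccc1C(=O)/C=C/c1ccc2ccccc2c1`, gives 42000 nM in an ADME assay on M210B4 cells (Mus musculus) for cytotoxicity, with a stated time of 48 h; on this read-out lower numbers stand for stronger inhibition and higher numbers for weaker inhibition.
Compound 2, `CCCOc1ccccc1C(=O)/C=C/c1ccc2ccccc2c1`, gives > 100000 nM, which is a limit of the assay rather than a number.
Compound 3, `CCCCOc1ccccc1C(=O)/C=C/c1ccc2ccccc2c1`, gives > 100000 nM, again a limit of the assay rather than a number.

Compound 3 therefore stands at the top end of what this assay can report, together with compound 2, while compound 1 is the only one of the three with a numerical value. The measured steps all lead away from compound 1: an at least 2.3-fold higher number from compound 1 to compound 2 (0.37 log units; beyond the scatter), and an at least 2.3-fold higher number from compound 1 to compound 3 (0.37 log units; beyond the scatter). The step between the two limit compounds is a step that the two limits leave unreadable from compound 2 to compound 3. Two of the three values sit at the limit of > 100000 nM in this assay, at which 2 of the 3 values shown sit.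

The unmeasured compound 4 is `CC(C)Oc1ccccc1C(=O)/C=C/c1ccc2ccccc2c1`. It differs from compound 3 by isopropyl in place of butyl on an oxygen on an aromatic ring. The isopropyl group falls in size between the methyl of compound 1 and the propyl of compound 2, and the steps from compound 1 show that replacing hydrogen on the chain carbon bound to the aromatic oxygen with ethyl or propyl already pushes the value past the limit. Compound 4 is therefore expected to stay near the limit, with a step that the limit leaves unreadable from compound 3 to compound 4. Compound 4 is estimated at 110000 nM, in the range 40000 nM to 300000 nM.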

Compound 4, half-maximal inhibitory concentration: > 100000 nM
Compound 4 gave a limit, no number; the forecaster's own chance of this, stated with the estimate: 60%; the middle value is on the limit's open side.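

Isopropyl is a branched group, and in this assay putting it in place of methyl on an oxygen on an aromatic ring gives an at least 2.3-fold higher number from compound 1 to compound 4 (0.37 log units; beyond the scatter), so the move away from compound 1 now holds for a branched group as well as for the straight propyl and butyl chains. The steps to compound 4 from compound 2 and from compound 3 cannot be read, as each has a limit at both ends, and so the branched group and the straight chains cannot be ranked against one another. Within the data shown here, compound 1 remains the only compound here with a real number, and the others all rest at the same ceiling: (the limit of > 100000 nM in this assay, at which 3 of the 4 values shown sit).

Still open, on these data alone, is where, on the way from methyl to propyl, the value passes out of the range of this read-out, a question that an ethyl group on this oxygen would bear on directly. Also open, as far as these compounds go, is whether a chain ending in an amine or a carboxylic acid at this place would bring the value back into the measurable range.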